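One Fluorine Relocated on Compound 3

The source may report more compounds than this note shows. Statements on the series, on what has been measured and on what is new or still open speak of the compounds shown alone.

Of the compounds shown here, three have been measured so far in a physicochemical assay for lipophilicity (a higher number here means a more lipophilic compound, a lower number a more polar compound), and give these values.

- Compound 1 `N#CC[C@@H]1CN(c2ccc3c(n2)NC(=O)CO3)[C@H](c2ccccc2)CO1` gives 2.3
- Compound 2 `C[C@@H]1CN(c2ncc3c(n2)NC(=O)CO3)[C@H](c2ccccc2)CO1` gives 2.7
- Compound 3 `C[C@@H]1CN(c2ccc3c(n2)NC(=O)CO3)[C@H](c2ccccc2F)CO1` gives 3.1

Compound 3 stands highest of the three, and its gaps to compound 2 and compound 1 both lie beyond the usual scatter. Compound 2 is the nearer of the two. No two of these compounds differ in only one place, so none of the gaps shows what a single change does.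

The next structure, compound 4 `C[C@@H]1CN(c2ccc3c(n2)NC(=O)CO3)[C@H](c2ccc(F)cc2)CO1`, has 4-fluorophenyl in place of 2-fluorophenyl on a saturated ring carbon and is otherwise the same as compound 3. The two have the same atoms, joined differently, and the group that changes sits on a saturated ring carbon next to the ring nitrogen. Among the compounds with values here, no measured pair tests such a swap, so the expectation starts from compound 3 at 3.1 and assumes little movement. The estimate is no change at the digits printed from compound 3 to compound 4 (within the scatter) in this assay, which would be no step beyond the scatter. For compound 4 the expected value is 3.1, with an estimated range from 2.8 to 3.4 around it.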

Compound 4, distribution coefficient: 3.2
Estimate against measurement, compound 4: 0.10 log units below, within the range that was stated.
By their numbers in this assay, from the lowest: compound 1; then compound 2; then compounds 3 and 4 (each within the scatter of the next).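

Within the data shown here, this is the first pair that differs in only one place, so a single change can finally be read on its own: 4-fluorophenyl in place of 2-fluorophenyl on a saturated ring carbon gives a number 0.10 log units higher from compound 3 to compound 4 (within the scatter) in this assay. That step lies within the scatter, so this assay does not separate compound 3 from compound 4, and these two placements of the fluorine on the phenyl ring cannot be told apart at this position. No measurement shown here offers an explanation for this result.

Among these compounds, the pair compares only two fluorophenyl groups, so it says nothing about whether the fluorine itself matters: compound 1 and compound 2 carry a plain phenyl group, but each also differs from compound 3 in other places, which leaves the plain phenyl group on the core of compound 3 as an open case. Also open, on these data alone, is how this assay would read with a quite different group on this same ring carbon, such as a phenyl ring bearing an amine or a carboxylic acid.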